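A Longer Acetamide Chain on a Weak Benzimidazole-Type Scaffold

The compounds below may be only part of what the source reports. "The series", "measured", "known", "first", "only" and "open" are said of these compounds alone.

Compound 1 `CCc1ccc2ncn(-c3ccnc(N)n3)c2c1` gives 79400 nM in an assay on Sf9 cells for inhibition of mitogen-activated protein kinase kinase kinase 14 variant S549D (Homo sapiens), with a stated time of 30 min, in the presence of a further agent that is not named here; a higher number here means a weaker inhibitor, a lower number a stronger inhibitor.
Compound 2 `C=CC(=O)NCCCCc1ccc2ncn(-c3ccnc(N)n3)c2c1` gives 501000 nM in this assay.
Compound 3 `CC(=O)NCCCc1ccc2ncn(-c3ccnc(N)n3)c2c1` reaches only a limit of the assay in this assay, namely > 100000 nM.

Compound 3 thus stands at the edge of what this assay can report: its value is a limit and not a number, as recorded in the limit of > 100000 nM in this assay, at which 1 of the 3 values shown sits. Compound 4 `CC(=O)NCCCCc1ccc2ncn(-c3ccnc(N)n3)c2c1` extends the chain of compound 3 by one link: acetamidomethyl in place of acetamido on a saturated chain carbon, three bonds along the chain from an aromatic carbon. Going by the values given here, two measured steps touch this chain. The step of an at least 1.2-fold higher number from compound 1 to compound 3 (0.10 log units; that floor lies within the scatter) adds the acetamide-bearing chain to the parent and barely moves beyond a floor that the scatter covers, while the step of a 6.3-fold higher number from compound 1 to compound 2 (0.80 log units; beyond the scatter) shows that a longer amide-bearing chain is tolerated only modestly. The step that the limit leaves unreadable from compound 2 to compound 3 cannot be read because of the limit. For compound 4 the expected step is a step that the limit leaves unreadable from compound 3 to compound 4, that is, little change, with a fair chance that this assay again reports only a limit. Compound 4 is therefore estimated at 200000 nM, within 60000 nM to 800000 nM.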

Compound 4, half-maximal inhibitory concentration: 398000 nM
Compound 4: middle estimate off by 2.0-fold (0.30 log units), on the low side; measured number inside the range.
By their numbers in this assay, from the lowest: compound 1; then compounds 4 and 2 (each within the scatter of the next).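

The 4-acetamidobutyl chain of compound 4 gives the acetamide series a readable number in this assay, and that number puts a size on what this chain costs relative to the ethyl parent: a 5.0-fold higher number from compound 1 to compound 4 (0.70 log units; beyond the scatter). Methyl in place of vinyl on the carbonyl carbon makes no readable difference, with a 1.3-fold lower number from compound 2 to compound 4 (0.10 log units; within the scatter). The steps from compound 3 to compound 4 and from compound 2 to compound 3 cannot be read, since the value of compound 3 is a limit of the assay: the limit of > 100000 nM in this assay, at which 1 of the 4 values shown sits.

The compounds shown leave open whether the true value of the 3-acetamidopropyl chain lies close to that of the 4-acetamidobutyl chain. They also leave open whether a chain ending in an amine or a carboxylic acid, rather than an amide, would match compound 1 at 79400 nM.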